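From a (4-chlorophenyl)carbamoyl to a (4-methoxyphenyl)carbonyl

This account rests on a few compounds, and the source may have more. Where it says the series, first, only, none or still open, it means among the compounds named here.

Of the compounds shown here, three sharing one core have been tested in an assay on LtK cells with ATP-sensitive inward rectifier potassium channel 11 (Homo sapiens) as the target; a higher number here means that more compound is needed for the effect, a lower number that less compound is needed. Compound 1 `C/C=C/C(=O)Nc1c(C(O)(C(F)(F)F)C(F)(F)F)ccc2ccccc12` gives 72 nM. Compound 2 `O=C(Nc1ccc(Cl)cc1)Nc1c(C(O)(C(F)(F)F)C(F)(F)F)ccc2ccccc12` gives 276 nM, the highest of the three numbers, so compound 2 needs the most material for the effect. Compound 3 `O=C(Nc1c(C(O)(C(F)(F)F)C(F)(F)F)ccc2ccccc12)c1cccc([N+](=O)[O-])c1` gives 117 nM. The steps between them are a 3.8-fold higher number from compound 1 to compound 2 (0.58 log units; beyond the scatter), a 1.6-fold higher number from compound 1 to compound 3 (0.21 log units; within the scatter) and a 2.4-fold lower number from compound 2 to compound 3 (0.37 log units; beyond the scatter).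

The new compound 4 `COc1ccc(C(=O)Nc2c(C(O)(C(F)(F)F)C(F)(F)F)ccc3ccccc23)cc1` departs from compound 2 in one place: 4-methoxyphenyl in place of (4-chlorophenyl)amino on a carbonyl carbon. The measured step that bears most directly on this change is a 2.4-fold lower number from compound 2 to compound 3 (0.37 log units; beyond the scatter), where the same (4-chlorophenyl)amino on the carbonyl carbon also gave way to a substituted phenyl. The step of a 1.6-fold higher number from compound 1 to compound 3 (0.21 log units; within the scatter) shows that two quite different groups on that carbonyl carbon can give numbers close to one another. Going by the values given here, no measured pair compares a 4-methoxyphenyl with a 3-nitrophenyl, so the size of that part of the change is unknown. A modest fall of roughly the size seen in a 2.4-fold lower number from compound 2 to compound 3 (0.37 log units; beyond the scatter) is therefore expected. The expected step is a 2.1-fold lower number from compound 2 to compound 4 (0.33 log units; beyond the scatter). Compound 4 is estimated at 130 nM, within a range from 50 nM to 350 nM.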

Compound 4, half-maximal effective concentration: 417 nM
For compound 4 the middle estimate is 3.2-fold (0.51 log units) below the measured one; the whole stated range lies below it.
By their numbers in this assay, from the lowest: compounds 1 and 3 (each within the scatter of the next); then compounds 2 and 4 (each within the scatter of the next).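

Exchanging the (4-chlorophenyl)amino, which carries a hydrogen-bond donor, for the 4-methoxyphenyl, which carries a hydrogen-bond acceptor and no donor, leaves the number within the scatter (a 1.5-fold higher number from compound 2 to compound 4 (0.18 log units; within the scatter)), so in this pair the change in those counts comes with no clear shift. The earlier step from compound 2 to compound 3 might have suggested that a substituted phenyl on this carbonyl carbon generally gives a lower number than the (4-chlorophenyl)amino, but compound 4 goes against that, and the two substituted phenyls themselves lie apart by more than the scatter (a 3.6-fold higher number from compound 3 to compound 4 (0.55 log units; beyond the scatter)). Compound 4 also lies well away from the prop-1-en-1-yl compound (a 5.8-fold higher number from compound 1 to compound 4 (0.76 log units; beyond the scatter)), the widest step among these four compounds, so what matters at this position is the particular group and not simply the presence of a phenyl ring.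

Nothing available explains why the numbers fall as they do at this position. Compound 3 and compound 4 differ both in the substituent on the phenyl and in where it sits, so a plain phenyl or a 4-nitrophenyl on the same carbonyl carbon would be needed to tell those two influences apart.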